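Compound 1 to compound 3: chloro in place of the amine

The source may report more compounds than this note shows. Statements on the series, on what has been measured and on what is new or still open speak of the compounds shown alone.

Two compounds of the series carry numbers in a functional assay (Homo sapiens) for inhibition of Nucleic Acid, tested at 100 uM; on this read-out lower numbers stand for less inhibition and higher numbers for more inhibition at the one concentration tested (going by the name of the read-out). Compound 1 `OCCNc1nccc2c1ncn2C1O[C@H](CO)[C@@H](O)[C@H]1O` gives 0% there, the lowest of the two; its nearest neighbour, compound 2 `CCCCCCNc1[nH]ccc2ncnc1-2`, gives 53%, a gap that lies beyond the scatter. For the measured compounds named here, compound 2 differs from compound 1 in more than one place, so no single step connects them, and nothing about the change below follows from that pair.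

Compound 3 `OC[C@H]1OC(n2cnc3c(Cl)nccc32)[C@H](O)[C@@H]1O` is not yet measured in this assay. It differs from compound 1 as follows: chloro in place of (2-hydroxyethyl)amino on an aromatic carbon. Going by the values given here, no measured pair shows this change, so its effect is unknown; compound 1 sits at the floor of the read-out, and a move downward cannot be read. The expectation is a small rise, with the step of a number 15 percentage points higher from compound 1 to compound 3 (beyond the scatter) possibly no larger than the scatter. Compound 3 is expected to give 15% in this assay, within a range from 0% to 45%.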

Compound 3, a percentage reported as inhibition, at one concentration (the size of the read-out at that concentration, not a potency): 76%
The estimate for compound 3 lay 61 percentage points below the measured number; measured number outside the range, above it.
By their numbers in this assay, from the lowest: compound 1; then compound 2; then compound 3.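

Chloro in place of (2-hydroxyethyl)amino on the aromatic carbon next to the ring nitrogen gives the first single-place comparison of the series in this assay, with a number 76 percentage points higher from compound 1 to compound 3 (beyond the scatter). For the compounds shown here, this position therefore has a strong bearing on the read-out, since this one change, with the rest of the core of compound 1 kept, separates a compound at the floor from the highest number so far, and the true size of the step may be hidden by that floor. No measurement is at hand that accounts for this step.

This single pair cannot separate the loss of (2-hydroxyethyl)amino from the arrival of chloro. A plain amine, a methoxy group, bromo or a longer aminoalkyl chain on the same carbon would show whether the number follows the halogen or only the absence of the hydroxyethyl chain.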